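The source may hold more compounds than are shown below. What is called first, only, known or untested is meant among the compounds shown, and "the series" means these compounds.

Measured in a functional assay on KB cells (Homo sapiens) for antiproliferative activity, read by sulforhodamine B assay, with a stated time of 3 days; a higher number here means that more compound is needed for the effect, a lower number that less compound is needed:
- compound 1 `CCC1=C(O)c2c(oc(-c3ccc(O)cc3)cc2=O)C(CC)(CC)C1=O`: 20.6 uM
- compound 2 `CCC1=C(O)c2c(oc(-c3ccc(OC(F)(F)F)cc3)cc2=O)C(CC)(CC)C1=O`: 36.5 uM
- compound 3 `CCC1=C(O)c2c(oc(-c3ccc(SC)cc3)cc2=O)C(CC)(CC)C1=O`: > 52.1 uM

Compound 3 has no number in this assay, only the limit > 52.1 uM. Compound 4 `CCC1=C(O)c2c(oc(-c3ccccc3C)cc2=O)C(CC)(CC)C1=O` carries 2-methylphenyl in place of 4-(methylsulfanyl)phenyl on the aromatic carbon next to the ring oxygen, (2-methylphenyl in place of 4-(methylsulfanyl)phenyl on an aromatic carbon). The measured steps that bear on this all alter that same phenyl group while the shared core stays fixed. They are a 1.8-fold higher number from compound 1 to compound 2 (0.25 log units; within the scatter), an at least 2.5-fold higher number from compound 1 to compound 3 (0.40 log units; beyond the scatter) and an at least 1.4-fold higher number from compound 2 to compound 3 (0.15 log units; that floor lies within the scatter). The largest of them is modest, although two of the three rest on the limit of compound 3, and none brings in 2-methylphenyl. These swaps give little reason to expect a large change in this assay. What is expected is therefore no step beyond the scatter, with a slight lean towards a lower number, estimated as an at least 1.3-fold lower number from compound 3 to compound 4 (0.13 log units; that floor lies within the scatter). Compound 4 is expected at 38 uM, with an estimated range from 15 uM to 80 uM.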

Compound 4, concentration for half-maximal effect: 40.9 uM
The estimate for compound 4 lay 1.1-fold (0.03 log units) below the measured number; low and high end bracket the measured number.
By their numbers in this assay, from the lowest: compounds 1, 2 and 4 (each within the scatter of the next). At a limit, above all of these: compound 3.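

On these data alone, the swap of 4-(methylsulfanyl)phenyl for 2-methylphenyl can be read only as a floor, an at least 1.2-fold lower number from compound 3 to compound 4 (0.10 log units; that floor lies within the scatter) in this assay, and its true size stays unknown because compound 3 has no number, only a limit: the limit of > 52.1 uM in this assay, at which 1 of the 4 values shown sits.
The change from 4-hydroxyphenyl to 2-methylphenyl gives a 2.0-fold higher number from compound 1 to compound 4 (0.30 log units; within the scatter) in this assay and so brings no step beyond the scatter.
Leaving the 4-substituted phenyl groups for 2-methylphenyl therefore does not, on these numbers, separate compound 4 from compound 1.

As far as these compounds go, only compound 4 carries a 2-substituted phenyl group, so it stays open whether 4-methylphenyl would behave like 2-methylphenyl.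
From the compounds shown here alone, it also stays open whether an amine or a carboxylic acid on this phenyl group would give a step beyond the scatter in this assay in either direction.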